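Hydroxy for fluoro on two cores: sulfonylurea receptor inhibition

The compounds below may be only part of what the source reports. "The series", "measured", "known", "first", "only" and "open" are said of these compounds alone.

Compound 1 `CC(O)(C(=O)Nc1ccc(S(=O)(=O)c2ccccc2F)cc1)C(F)(F)F` and compound 2 `CC(O)(C(=O)Nc1ccc(S(=O)(=O)c2ccccc2O)cc1)C(F)(F)F` share one core; compound 3 `CC(O)(C(=O)Nc1ccc(C(=O)c2ccccc2)c(F)c1)C(F)(F)F` and compound 4 `CC(O)(C(=O)Nc1ccc(C(=O)c2ccccc2)c(O)c1)C(F)(F)F` share another, and the difference between the two cores is not broken down here. In a functional assay (Cavia porcellus) with sulfonylurea receptors; K-ATP channels (Homo sapiens) as the target (on this read-out higher numbers stand for weaker inhibition and lower numbers for stronger inhibition), compound 1 gives 1300 nM and compound 2 gives 3090 nM; the change hydroxy in place of fluoro on an aromatic carbon made a step of a 2.4-fold higher number from compound 1 to compound 2 (0.38 log units; beyond the scatter). In this assay compound 3 gives 2700 nM. The change to compound 4, (hydroxy in place of fluoro on an aromatic carbon), is the same kind of change, but it sits ortho to a benzoyl group and meta to a large group, whereas in compound 2 it sits ortho to a large group. For compound 4 a step of about a 2.4-fold higher number from compound 3 to compound 4 (0.38 log units; beyond the scatter) is expected, resting only on the step from compound 1 to compound 2. Compound 4 is therefore estimated at 6500 nM, between 2700 nM and 15000 nM.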

Compound 4, half-maximal inhibitory concentration: 4200 nM
The estimate for compound 4 lay 1.5-fold (0.19 log units) above the measured number; low and high end bracket the measured number.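

In this assay hydroxy in place of fluoro on an aromatic carbon gives a 1.6-fold higher number from compound 3 to compound 4 (0.19 log units; within the scatter) on the second core, and the two steps do not separate: the same change on two cores in this assay, a 2.4-fold higher number (0.38 log units; beyond the scatter) from compound 1 to compound 2 and a 1.6-fold higher number (0.19 log units; within the scatter) from compound 3 to compound 4, 1.5-fold (0.18 log units) apart, within the scatter of two such steps. The change therefore carries from the core of compound 1 to the core of compound 3 with no difference in step size that can be read. This rests on two pairs only, with one step beyond the scatter and the other within it, and it does not show that the step would hold on any further core or at any other place on the ring.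

Still open, as far as these compounds go, is how a methoxy group or an amine in the same place would compare with hydroxy and fluoro. Also open, from the compounds shown here alone, is whether the step persists when the trifluoromethyl carbinol amide is replaced, for example by a carboxylic acid.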